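Swapping the Benzofuran Arm for an Ethoxyphenyl

A few compounds are considered here, and "the series" means these few. Any claim that something is new, unique, unknown or untested is made for them only; others in the source may bear on it.

Of the compounds shown here, three built on one shared core have been measured in an assay on isolated protein for agonist activity at Bile acid receptor (Homo sapiens), read by AlphaScreen, with a stated time of 30 min; a lower number here means that less compound is needed, a higher number that more compound is needed for the effect. Compound 1 `CCc1ccccc1-n1nc(C)c2c1NC(=O)[C@H](C)S[C@@H]2c1ccc(Oc2ccccc2)cc1` gives 1100 nM, compound 2 `Cc1ccccc1-n1nc(C)c2c1NC(=O)[C@H](C)S[C@@H]2c1ccc(-c2cc3ccccc3o2)cc1` gives 1500 nM, and compound 3 `Cc1nn(-c2ccccc2F)c2c1C(c1ccc(Oc3ccccc3)cc1)SC(C)C(=O)N2` gives 3900 nM. Compound 2 thus holds the second highest of the three numbers; its nearest neighbour is compound 1, whose number lies within the usual scatter of it, while compound 3 sits furthest off, with a number beyond the scatter above that of compound 2.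

Compound 4 `CCOc1cccc(-c2ccc([C@H]3S[C@@H](C)C(=O)Nc4c3c(C)nn4-c3ccccc3C)cc2)c1` has not yet been measured. It differs from compound 2 in a single place: 3-ethoxyphenyl in place of 1-benzofuran-2-yl on an aromatic carbon, para to a large group. Going by the values given here, no measured pair isolates this change, so the expectation rests on the values at hand. Compound 1 gives 1100 nM and sits within the scatter of compound 2, so the arms seen so far do not swing the number widely. The step of a 1.3-fold lower number from compound 2 to compound 4 (0.10 log units; within the scatter) is expected to be small and towards a slightly lower number, with no confidence that it leaves the scatter. For compound 4 the estimate in this assay is 1200 nM, within 500 nM to 3000 nM.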

Compound 4, half-maximal effective concentration: 3500 nM
For compound 4 the middle estimate is 2.9-fold (0.46 log units) below the measured one, outside the stated range (above it).
By their numbers in this assay, from the lowest: compounds 1 and 2 (each within the scatter of the next); then compounds 4 and 3 (each within the scatter of the next).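

Going by these compounds alone, this position, on an aromatic carbon para to a large group, gives the first single change that can be read. In this assay, replacing 1-benzofuran-2-yl with 3-ethoxyphenyl gives a 2.3-fold higher number from compound 2 to compound 4 (0.37 log units; beyond the scatter), a modest step, which shows that the number responds to this exchange even though the two groups have the same counts of heavy atoms, carbon, oxygen, hydrogen-bond donors and hydrogen-bond acceptors. The exchange does change the ring make-up, from one five-membered and one six-membered aromatic ring to a single six-membered aromatic ring, but nothing available explains why the number moves.

The compounds shown leave open whether the step follows from the loss of the five-membered aromatic ring or from the ethoxy chain and where it sits on the phenyl ring. A plain phenyl, a 3-methoxyphenyl, a 4-ethoxyphenyl or a phenyl bearing a carboxylic acid at this same position, on the core of compound 2, would help to separate these possibilities.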